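Aryl in place of benzyl on the ring amine

This account rests on a few compounds, and the source may have more. Where it says the series, first, only, none or still open, it means among the compounds named here.

Compound 1 `CCCn1c(=O)[nH]c2nc(-c3ccc(S(=O)(=O)N4CCN(Cc5cccc(C)c5)CC4)cc3)[nH]c2c1=O`: 795 nM
Compound 2 `CCCn1c(=O)[nH]c2nc(-c3ccc(S(=O)(=O)N4CCN(c5ccccc5C)CC4)cc3)[nH]c2c1=O`: 419 nM
Compound 3 `CCCn1c(=O)[nH]c2nc(-c3ccc(S(=O)(=O)N4CCN(c5cccc(Br)c5)CC4)cc3)[nH]c2c1=O`: > 1000 nM (a limit)

In an assay on CHO cells for displacement of a labelled ligand from adenosine receptor A1 (Homo sapiens), read by scintillation counting, with a stated time of 90 min, in the presence of a further agent that is not named here (a higher number here means a weaker inhibitor, a lower number a stronger inhibitor), compound 1 stands highest of the two numbers shown, with compound 2 nearest; the step of a 1.9-fold lower number from compound 1 to compound 2 (0.28 log units; within the scatter) lies within the scatter. For compound 3 this assay reports only a limit, (the limit of > 1000 nM in this assay, at which 1 of the 3 values shown sits). The step of an at least 1.2-fold higher number from compound 1 to compound 3 (0.09 log units; that floor lies within the scatter) is within the scatter, whereas an at least 2.3-fold higher number from compound 2 to compound 3 (0.37 log units; beyond the scatter) goes beyond it.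

Compound 4 `CCCn1c(=O)[nH]c2nc(-c3ccc(S(=O)(=O)N4CCN(c5ccc(C)cc5)CC4)cc3)[nH]c2c1=O` changes compound 1 by 4-methylphenyl in place of 3-methylbenzyl on an amine nitrogen in a ring. Both measured steps away from compound 1 stayed within the scatter, so no change beyond it is expected here. Compound 4 is expected to give about 600 nM, between 250 nM and 1500 nM. The expected step of a 1.3-fold lower number from compound 1 to compound 4 (0.12 log units; within the scatter) would remain within the scatter.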

Compound 4, inhibition constant: > 1000 nM
Compound 4 ended at the assay's limit; the forecaster's own chance of this, stated with the estimate: 15%; middle value at least 1.6-fold (0.22 log units) from the limit.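

In this assay the 4-methylphenyl group parts from the 2-methylphenyl group, with an at least 2.3-fold higher number from compound 2 to compound 4 (0.37 log units; beyond the scatter) separating them, so the place of the methyl on the aryl group counts here. Against the 3-methylbenzyl group, an at least 1.2-fold higher number from compound 1 to compound 4 (0.09 log units; that floor lies within the scatter) gives only a floor within the scatter, so no real change from that group can be claimed. Compound 3 and compound 4 both stand at a limit, and the step between them cannot be read: the limit of > 1000 nM in this assay, at which 2 of the 4 values shown sit.

Still open, on these data alone, is how far compound 4 lies past its limit. Also open, as far as these compounds go, is how 3-methylphenyl, or a phenyl carrying a methoxy group or an amine in place of the methyl, would read here.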